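The compounds below may be only part of what the source reports. "The series", "measured", "known", "first", "only" and "open" are said of these compounds alone.

Measured so far in a functional assay on SW 1116 cells (Homo sapiens) for cytotoxicity, read by MTT assay, with a stated time of 48 h; on this read-out lower numbers stand for stronger inhibition and higher numbers for weaker inhibition:
- compound 1, `O=C(CSc1nnc(-c2ccncc2)o1)N/N=C/c1ccc(F)cc1`: 15700 nM
- compound 2, `Cc1ccc(/C=N/NC(=O)CSc2nnc(-c3ccncc3)o2)cc1`: 16800 nM
- compound 3, `O=C(CSc1nnc(-c2ccncc2)o1)N/N=C/c1ccc(O)c(O)c1`: 1540 nM

Compound 3 gives the lowest number of the three and is the most potent of the set in this assay, as its steps to both other compounds lie beyond the scatter: a 10-fold lower number from compound 1 to compound 3 (1.01 log units; beyond the scatter) and an 11-fold lower number from compound 2 to compound 3 (1.04 log units; beyond the scatter). By contrast, a 1.1-fold higher number from compound 1 to compound 2 (0.03 log units; within the scatter), so the exchange of one para substituent for another on that ring did not move the read-out.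

Compound 4, `COc1cc(/C=N/NC(=O)CSc2nnc(-c3ccncc3)o2)ccc1O`, is the next point. The change from compound 3 is methyl in place of hydrogen on an oxygen on an aromatic ring; read one bond further out, it turns hydroxy into methoxy, 3,4-dihydroxyphenyl into 4-hydroxy-3-methoxyphenyl. For the measured compounds named here, no measured step covers this particular change. What is known is that the pair of hydroxy groups is what sets compound 3 apart from compound 1 and compound 2 by a large margin; capping one of them with methyl removes part of that feature, though the second hydroxy remains. A loss of some size is therefore expected rather than a gain, but well short of a return to the level of compound 1.

Expected for compound 4 in this assay: a 2.6-fold higher number from compound 3 to compound 4 (0.41 log units; beyond the scatter), giving an estimate of 4000 nM with a range from 1500 nM to 12000 nM.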

Compound 4, half-maximal inhibitory concentration: 3590 nM
Beside the measured number, compound 4's estimate is 1.1-fold (0.05 log units) above it; the range from low to high includes it.
By their numbers in this assay, from the lowest: compound 3; then compound 4; then compounds 1 and 2 (each within the scatter of the next).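

In this assay, for the compounds shown here, methyl on this oxygen gives a 2.3-fold higher number from compound 3 to compound 4 (0.37 log units; beyond the scatter) as a modest step, so a single added carbon on one hydroxy of the 3,4-dihydroxyphenyl group is enough to move the read-out beyond the scatter, which no earlier pair could show. The 4-hydroxy-3-methoxyphenyl group nevertheless keeps a clear lead over the two singly substituted rings, with a 4.7-fold lower number from compound 2 to compound 4 (0.67 log units; beyond the scatter) on replacing 4-methylphenyl and a 4.4-fold lower number from compound 1 to compound 4 (0.64 log units; beyond the scatter) on replacing 4-fluorophenyl, so most of the gain seen with compound 3 does not depend on both hydroxy groups remaining free. No supporting data are available to account for the size of any of these steps.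

The compounds shown leave open whether the change in the read-out follows the loss of the hydroxy hydrogen or the added methyl itself, a question that ethoxy or a longer alkoxy chain on the same oxygen, or an amine in place of that hydroxy, would address. They also leave open whether the other hydroxy behaves alike, as 3-hydroxy-4-methoxyphenyl and 3,4-dimethoxyphenyl would show on the same core.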